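The compounds below may be only part of what the source reports. "The series", "measured", "known", "first", "only" and "open" are said of these compounds alone.

Series notes, sulfonyl-piperazine quinazolines

Among the compounds with values here, the shared core carries an aryl group on a sulfonyl sulfur, and only that aryl group varies. Compound 1 `COc1cc2nc(N3CCN(S(=O)(=O)c4ccc(I)cc4)CC3)nc(N)c2cc1OC` bears a 4-iodophenyl there; in a functional assay on PC-3 cells (Homo sapiens) for inhibition (on this read-out lower numbers stand for stronger inhibition and higher numbers for weaker inhibition), compound 1 gives 15000 nM. Compound 2 `COc1cc2nc(N3CCN(S(=O)(=O)c4cccc([N+](=O)[O-])c4)CC3)nc(N)c2cc1OC` bears a 3-nitrophenyl; in this assay compound 2 gives 32000 nM. Within the data shown here, the one measured step, a 2.1-fold higher number from compound 1 to compound 2 (0.33 log units; beyond the scatter), is modest but beyond the scatter. Among the measured compounds shown here, compound 2 therefore stands as the highest of the two numbers so far, with compound 1 as its nearest neighbour at a lower number.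

Compound 3 `COc1cc2nc(N3CCN(S(=O)(=O)c4ccc(C(F)(F)F)cc4)CC3)nc(N)c2cc1OC` is the next member. Its change from compound 2 is 4-(trifluoromethyl)phenyl in place of 3-nitrophenyl on a sulfonyl sulfur. For the measured compounds named here, only the step from compound 1 to compound 2 bears on this change, since both involve swapping the aryl group on the sulfonyl sulfur, and that step was modest. The expectation for this assay is accordingly a modest step, toward a lower number, because compound 1 with its 4-iodophenyl gives 15000 nM and compound 3 likewise carries a single substituent on the phenyl. The estimated step is a 1.8-fold lower number from compound 2 to compound 3 (0.25 log units; within the scatter). Compound 3 is expected to give about 18000 nM, within a range of 7000 nM to 45000 nM.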

Compound 3, half-maximal inhibitory concentration: 27000 nM
Compound 3: the middle estimate sits 1.5-fold (0.18 log units) below what was measured; the measured number falls inside the stated range.
By their numbers in this assay, from the lowest: compounds 1, 3 and 2 (each within the scatter of the next, the first and the last beyond it).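

In this assay the exchange of 3-nitrophenyl for 4-(trifluoromethyl)phenyl on the sulfonyl sulfur amounts to (a 1.2-fold lower number from compound 2 to compound 3 (0.07 log units; within the scatter)), and trifluoromethyl in place of iodo on an aromatic carbon amounts to (a 1.8-fold higher number from compound 1 to compound 3 (0.26 log units; within the scatter)). Compound 3 therefore cannot be separated from either neighbour, although those two neighbours are themselves separated by (a 2.1-fold higher number from compound 1 to compound 2 (0.33 log units; beyond the scatter)), so that single step beyond the scatter gives no firm ordering of the aryl groups at this position. The group leaving in the exchange carries hydrogen-bond acceptors and the entering group carries none, yet the numbers stay within the scatter of each other, and no measurement at hand offers an explanation for these numbers.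

The compounds shown all keep a singly substituted phenyl on the sulfonyl sulfur, so the effect of a phenyl bearing an amine or a carboxylic acid remains open. Also open, going by these compounds, is whether a straight alkyl chain in place of the aryl group, or a second substituent on the phenyl, would move the number well away from this narrow band.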